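Amide variation on a shared core at GPR39

The compounds below may be only part of what the source reports. "The series", "measured", "known", "first", "only" and "open" are said of these compounds alone.

Measured compounds:
- compound 1 `Cc1nn(-c2ncnc3nc[nH]c23)c2c1C(OCc1cc(F)cc3c1OCOC3)CC(=O)N2`: 1.5 nM
- compound 2 `CCC(C(=O)NC1CC(=O)Nc2c1c(C)nn2-c1ncnc2nc[nH]c12)c1ccccc1`: 5 nM
- compound 3 `C=CCN1c2c(n(C)c(=O)n(C)c2=O)NC1N/N=C/c1ccc(O)cc1O`: 340 nM

In a functional assay on HEK293 cells for agonist activity at G-protein coupled receptor 39 (Homo sapiens), read by scintillation proximity assay and inositol phosphate accumulation, with a stated time of 75 min, in the presence of a further agent that is not named here (on this read-out higher numbers stand for an effect only at larger amounts of compound and lower numbers for an effect already at smaller amounts), compound 2 gives 5 nM, the second highest of the three numbers; compound 1 sits at a lower number and compound 3 at a much higher one, both gaps beyond the usual scatter. Compound 4 `Cc1nn(-c2ncnc3nc[nH]c23)c2c1C(NC(=O)c1ccccc1)CC(=O)N2` has not yet been measured. It differs from compound 2 in one place: phenyl in place of 1-phenylpropyl on a carbonyl carbon. Among the measured compounds shown here, no measured pair shows the same change, so the size of the step is open. The shorter side group is expected to give a modest move toward higher numbers, likely just beyond the scatter, with the estimated step of a 4.0-fold higher number from compound 2 to compound 4 (0.60 log units; beyond the scatter). Compound 4 is therefore expected to give 20 nM, within a range from 5 nM to 80 nM.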

Compound 4, half-maximal effective concentration: 3 nM
The estimate for compound 4 lay 6.7-fold (0.82 log units) above the measured number; the whole stated range lies above it.
By their numbers in this assay, from the lowest: compounds 1, 4 and 2 (each within the scatter of the next, the first and the last beyond it); then compound 3.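

In this assay, phenyl in place of 1-phenylpropyl on a carbonyl carbon gives a 1.7-fold lower number from compound 2 to compound 4 (0.22 log units; within the scatter) and so leaves the number unchanged within the scatter. At this place, the amide series therefore holds its low nanomolar number with the smaller phenyl group, and the extra carbons of 1-phenylpropyl are not needed to keep it. Nothing available here explains this result. Going by these compounds, what an amine or a carboxylic acid on the phenyl ring would do stays open. So does whether the aromatic ring is needed at all, which a plain methyl group on the carbonyl carbon would address.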